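Chain or aryl on the ether: expected step to compound 4

This account rests on a few compounds, and the source may have more. Where it says the series, first, only, none or still open, it means among the compounds named here.

Values in an ADME assay on KB cells (Homo sapiens) for cytotoxicity; a lower number here means that less compound is needed, a higher number that more compound is needed for the effect
compound 1 `COc1ccc(COc2c(OC)c(OC)cc3c2C(=O)[C@]2(OC)C=C[C@H]3N(C(=O)OCC(C)C)N2C(=O)OCC(C)C)cc1` gives 47.9 ug/mL
compound 2 `CCCCOc1c(OC)c(OC)cc2c1C(=O)[C@]1(OC)C=C[C@H]2N(C(=O)OCC(C)C)N1C(=O)OCC(C)C` gives 22.1 ug/mL
compound 3 `COc1cc2c(c(OCc3ccccc3F)c1OC)C(=O)[C@]1(OC)C=C[C@H]2N(C(=O)OCC(C)C)N1C(=O)OCC(C)C` gives 109 ug/mL

Compound 3 at 109 ug/mL holds the highest number of the three, and its gaps to both others lie beyond the scatter. Next comes compound 4 `CCCOc1c(OC)c(OC)cc2c1C(=O)[C@]1(OC)C=C[C@H]2N(C(=O)OCC(C)C)N1C(=O)OCC(C)C`, still unmeasured in this assay and differing from compound 3 as follows: ethyl in place of 2-fluorophenyl on a saturated chain carbon bound to an oxygen on an aromatic ring.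

Within the data shown here, two measured steps bear on this. The closest is a 4.9-fold higher number from compound 2 to compound 3 (0.69 log units; beyond the scatter), where 2-fluorophenyl takes the place of propyl at that carbon, the opposite kind of exchange. The other is a 2.2-fold lower number from compound 1 to compound 2 (0.34 log units; beyond the scatter), where propyl replaces 4-methoxyphenyl and the number falls. Among the measured compounds shown here, in both, the compound with the chain has the lower number, though compound 2 at 22.1 ug/mL is the only measured compound with a chain, and no measured step varies its length.

A step to a lower number is therefore expected in this assay, close in size to the closest step. The expected step is a 4.4-fold lower number from compound 3 to compound 4 (0.64 log units; beyond the scatter) and carries the uncertainty of that single chain example. For compound 4 the estimated value is 25 ug/mL, with an expected range from 12 ug/mL to 55 ug/mL and the measurement still to come.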

Compound 4, concentration for half-maximal effect: 299 ug/mL
For compound 4 the middle estimate is 12-fold (1.08 log units) below the measured one; measured number outside the range, above it.
By their numbers in this assay, from the lowest: compound 2; then compound 1; then compound 3; then compound 4.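

In this assay, the largest step among these compounds comes from the loss of a single methyl, hydrogen in place of methyl on a saturated chain carbon, three bonds along the chain from an oxygen on an aromatic ring (a 14-fold higher number from compound 2 to compound 4 (1.13 log units; beyond the scatter)). A chain at this position therefore does not go with the lower numbers as such: ethyl in place of 2-fluorophenyl gives one higher number (a 2.7-fold higher number from compound 3 to compound 4 (0.44 log units; beyond the scatter)), and ethyl in place of 4-methoxyphenyl gives another (a 6.2-fold higher number from compound 1 to compound 4 (0.80 log units; beyond the scatter)), the reverse of the direction seen with propyl against the same two aryl groups. The order of chain and aryl at this carbon thus turns on which chain is present, with compound 2 below both aryl compounds and compound 4 above both, a reading that rests on these two chain compounds alone.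

Nothing measured here accounts for the gap between the two chains. Going by these compounds, whether compound 2 is an isolated low point or part of a trend with length stays open, and a pentyl or hexyl chain at the same carbon would bear on that in this assay.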